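A few compounds are considered here, and "the series" means these few. Any claim that something is new, unique, unknown or untested is made for them only; others in the source may bear on it.

Measured so far:

Compound 1 `O=C1c2sc(C#Cc3ccccc3)nc2CN1C1CC1` gives 23 nM in an assay on HEK293 cells for negative allosteric modulation of metabotropic glutamate receptor 5 (Homo sapiens), read by FLIPR, with a stated time of 1 h; a higher number here means a weaker inhibitor, a lower number a stronger inhibitor.
Compound 2 `O=C(C1CC12CCC2)N1CCc2nc(C#Cc3ccccc3)sc2C1` gives only a limit of the assay, > 10000 nM, in this assay.
Compound 3 `O=C(C1CC(F)(F)C1)N1CCc2nc(C#Cc3cccc(F)c3)sc2C1` gives only a limit of the assay, > 10000 nM, in this assay.

Compound 2 therefore stands at the limit of this assay rather than at a number, and it shares that limit with one other value shown (the limit of > 10000 nM in this assay, at which 2 of the 3 values shown sit). Compound 4 `O=C(C1CCOCC1)N1CCc2nc(C#Cc3ccccc3)sc2C1` has not yet been measured in this assay. It differs from compound 2 at one place only: a group of 6 heavy atoms (5 carbon, 1 oxygen; one six-membered non-aromatic ring with 1 hetero atom) in place of a group of 6 heavy atoms (6 carbon; one three-membered non-aromatic ring of carbon only, one four-membered non-aromatic ring of carbon only), on a carbonyl carbon. No step between two measured compounds is shown, so the size of this change cannot be read from a neighbouring pair. Compound 3, which carries a different ring on the same carbonyl carbon within the same core as compound 2, also sits at the limit (the limit of > 10000 nM in this assay, at which 2 of the 3 values shown sit). On that basis compound 4 is expected to stay near the limit, with no step beyond the scatter: the step from compound 2 to compound 4 is estimated as a number no higher from compound 2 to compound 4 (the limit leaves the size open). For compound 4 the estimated value in this assay is 10000 nM, within a range from 3000 nM to 30000 nM.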

Compound 4, half-maximal inhibitory concentration: > 10000 nM
Compound 4 was reported as a limit (the forecaster's own chance of this, stated with the estimate: 70%); the middle value sits exactly at the limit.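

Compound 2 and compound 4 both sit at a limit of the assay rather than at a number, so no step between them can be read: the limit of > 10000 nM in this assay, at which 3 of the 4 values shown sit.

The compounds shown leave open whether placing oxan-4-yl on the carbonyl carbon changes inhibition at all.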